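The compounds below may be only part of what the source reports. "The series", "measured", "known", "first", "only" and "open" are said of these compounds alone.

In a functional assay on K562 cells (Homo sapiens) for antiproliferative activity, read by MTT assay, with a stated time of 48 h (on this read-out lower numbers stand for stronger inhibition of growth and higher numbers for weaker inhibition of growth), compound 1 (`CCOc1cc(NC(=O)CCCCCC(=O)Nc2cc(-c3ccccc3)ccc2N)cc2c1OCC([N+](=O)[O-])=C2`) gives 3210 nM. Compound 2 (`CCOc1cc(NC(=O)CCCCCCC(=O)Nc2ccccc2N)cc2c1OCC([N+](=O)[O-])=C2`) gives 3360 nM, and compound 3 (`CCOc1cc(NC(=O)CCCCC(=O)Nc2cc(-c3ccc(C)s3)ccc2N)cc2c1OCC([N+](=O)[O-])=C2`) gives 2940 nM. Compound 1 therefore stands within the scatter of both others, and the three values do not separate.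

Compound 4 (`CCOc1cc(NC(=O)CCCCCC(=O)Nc2cc(-c3ccc(C)s3)ccc2N)cc2c1OCC([N+](=O)[O-])=C2`) alters compound 1 in one place: 5-methylthiophen-2-yl in place of phenyl on an aromatic carbon. In words, this is 5-methylthiophen-2-yl in place of phenyl on an aromatic carbon. Among the measured compounds shown here, no measured pair isolates this change. Compound 3 carries the same 5-methylthiophen-2-yl group on a different chain and gives 2940 nM, so no step beyond the scatter is expected in this assay.

The expected change is a 1.1-fold lower number from compound 1 to compound 4 (0.03 log units; within the scatter). For compound 4 the estimated value is 3000 nM, with an expected range of 1700 nM to 5200 nM.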

Compound 4, concentration for 50% growth inhibition: 2920 nM
The estimate for compound 4 lay 1.0-fold (0.01 log units) above the measured number, and the stated range covers the measured number.
By their numbers in this assay, from the lowest: compounds 4, 3, 1 and 2 (each within the scatter of the next).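

On the aromatic carbon para to an amino group, 5-methylthiophen-2-yl in place of phenyl gives a 1.1-fold lower number from compound 1 to compound 4 (0.04 log units; within the scatter) in this assay. The earlier compounds shown here held no pair isolating this change; with the chain held constant, the two groups now show no separation at this position. No measurement at hand gives a reason for this result.

As far as these compounds go, whether a carboxylic acid or a morpholine on this aromatic carbon would also stay within the scatter remains open. So does the outcome of replacing the ethoxy group on the shared core with a hydroxyl.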